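Swapping the Halogen and Its Ring Position on the Aryl Urea

The source may report more compounds than this note shows. Statements on the series, on what has been measured and on what is new or still open speak of the compounds shown alone.

Among the compounds with values here, compound 3 `COc1cc(NC(C)CCCNC(=O)Nc2cccc(F)c2)c2ncccc2c1` gives 27000 nM in a functional assay on SW-620 cells (Homo sapiens) for inhibition, read by MTT assay, with a stated time of 72 h (on this read-out higher numbers stand for weaker inhibition and lower numbers for stronger inhibition), the highest of the three numbers so far. Compound 2 `COc1cc(NC(C)CCCNC(=O)NNC(=O)Nc2cccc(Cl)c2)c2ncccc2c1` gives 25000 nM, and the gap a 1.1-fold higher number from compound 2 to compound 3 (0.03 log units; within the scatter) lies within the scatter, whereas compound 1 `COc1cc(NC(C)CCCNC(=O)NNC(=O)Nc2cccc(F)c2)c2ncccc2c1` gives 9500 nM, so that a 2.8-fold higher number from compound 1 to compound 3 (0.45 log units; beyond the scatter). Compound 4 `COc1cc(NC(C)CCCNC(=O)Nc2ccc(Cl)cc2)c2ncccc2c1` differs from compound 3 in one place: 4-chlorophenyl in place of 3-fluorophenyl on an amide-type nitrogen. Within the data shown here, the only measured step that bears on this is the halogen exchange, a 2.6-fold higher number from compound 1 to compound 2 (0.42 log units; beyond the scatter), a modest rise. Among the measured compounds shown here, no measured pair compares a 3-fluorophenyl with a 4-chlorophenyl directly, so the change in where the halogen sits stays untested. A modest rise beyond the scatter is therefore expected, a 1.5-fold higher number from compound 3 to compound 4 (0.17 log units; within the scatter). Compound 4 is estimated at 40000 nM, with a range from 13000 nM to 120000 nM.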

Compound 4, half-maximal inhibitory concentration: 28000 nM
Estimate against measurement, compound 4: 1.4-fold (0.15 log units) above; low and high end bracket the measured number.
By their numbers in this assay, from the lowest: compound 1; then compounds 2, 3 and 4 (each within the scatter of the next).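

In this assay, a step of a 1.0-fold higher number from compound 3 to compound 4 (0.02 log units; within the scatter) shows that 4-chlorophenyl and 3-fluorophenyl on this amide-type nitrogen read alike, even with the halogen and its ring position exchanged together. The same holds for a 1.1-fold higher number from compound 2 to compound 4 (0.05 log units; within the scatter) and, of these new steps, only a 2.9-fold higher number from compound 1 to compound 4 (0.47 log units; beyond the scatter) lies beyond the scatter. No supporting data explain this pattern.

The halogen and its position change in one step, so their separate contributions remain unresolved. Also open, going by these compounds, is how 3-chlorophenyl, or a phenyl ring carrying an amine or a carboxylic acid, would read on this nitrogen.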